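The source may report more compounds than this note shows. Statements on the series, on what has been measured and on what is new or still open speak of the compounds shown alone.

Measured in a functional assay on A549 cells (Homo sapiens) for cytotoxicity, read by MTT assay, with a stated time of 48 h; on this read-out higher numbers stand for weaker inhibition and lower numbers for stronger inhibition:
- compound 1 `CCOC(=O)[C@@]1(C(=O)Nc2ccccc2Cl)C[C@@H]1c1cc(OC)c(OC)c(OC)c1` gives 29000 nM
- compound 2 `COc1cc([C@H]2C[C@@]2(CO)C(=O)Nc2ccccc2Cl)cc(OC)c1OC` gives > 100000 nM (a limit)

Among the measured compounds shown here, compound 1 at 29000 nM is the only actual number so far. Compound 2 stands at > 100000 nM, which is a limit of the assay. Compound 3 `CCOC(=O)[C@@]1(C(=O)Nc2ccccc2Cl)C[C@H]1c1cc(OC)c(OC)c(OC)c1` is not yet measured. Its difference from compound 1 is the two compounds have the same atoms and bonds and differ only in configuration as drawn: 1 of 2 stereo elements differ; a stereocentre at a saturated ring carbon is drawn R in compound 1 and S in compound 3, with a stereocentre at a saturated ring carbon drawn R in compound 1 and S in compound 3. For the measured compounds named here, the one measured step, an at least 3.4-fold higher number from compound 1 to compound 2 (0.53 log units; beyond the scatter), puts hydroxymethyl in place of ethoxycarbonyl, so it is a change of group and gives no direct measure of a change in configuration. The estimated step is a 1.4-fold higher number from compound 1 to compound 3 (0.16 log units; within the scatter), expected to stay within the scatter, with a slight lean to a higher number. Compound 3 is expected at 42000 nM, with an estimated range of 13000 nM to 100000 nM in this assay.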

Compound 3, half-maximal inhibitory concentration: 17600 nM
Compound 3: the middle estimate sits 2.4-fold (0.38 log units) above what was measured; the measured number falls inside the stated range.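

In this assay, redrawing one stereocentre at a saturated ring carbon from R to S gives a 1.6-fold lower number from compound 1 to compound 3 (0.22 log units; within the scatter), so this change of configuration does not separate the two compounds in this assay. Among the compounds shown here, this pair gives a direct reading of configuration at this position, which the change from ethoxycarbonyl to hydroxymethyl could not provide, as no group changes here: the fact that compounds 1 and 3 differ only in the configuration as drawn Compound 2, at > 100000 nM, is a limit of the assay, so the only numeric reading of configuration comes with ethoxycarbonyl in place.

Going by these compounds, whether configuration at this carbon also stays within the scatter with a carboxylic acid or a primary amide in place of ethoxycarbonyl remains open. Also open, on these data alone, is how the other stereo element, drawn the same in compounds 1 and 3, bears on the number in this assay.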